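The source may report more compounds than this note shows. Statements on the series, on what has been measured and on what is new or still open speak of the compounds shown alone.

Three biphenyl-type phenols were measured in an ADME assay on HEK293 cells (Homo sapiens) for cytotoxicity, read by MTT assay, with a stated time of 3 days; a lower number here means a stronger inhibitor, a higher number a weaker inhibitor. Compound 1 `COc1ccc(-c2cccc(O)c2)cc1` gives 14.6 ug/mL. Compound 2 `COc1cccc(-c2ccc(O)cc2)c1` gives 35 ug/mL; compound 1 and compound 2 are built from the same atoms joined differently, and the difference between the two cores is not broken down here. Compound 3 `Nc1ccc(-c2cccc(O)c2)cc1` gives 55 ug/mL.

From compound 1 to compound 3 the change is amino in place of methoxy on an aromatic carbon, and it produced a 3.8-fold higher number from compound 1 to compound 3 (0.58 log units; beyond the scatter). Compound 4 `Nc1cccc(-c2ccc(O)cc2)c1` has not yet been measured in this assay. It differs from compound 2 by amino in place of methoxy on an aromatic carbon, the same kind of change as that from compound 1 to compound 3, although the group there sits para to the group of 7 heavy atoms, whereas in compound 4 it sits meta to it.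

In this assay an estimated step of a 2.6-fold higher number from compound 2 to compound 4 (0.41 log units; beyond the scatter) is expected from compound 2 to compound 4, because the change from compound 1 to compound 3 gave a 3.8-fold higher number from compound 1 to compound 3 (0.58 log units; beyond the scatter). Compound 4 is accordingly estimated to give about 90 ug/mL, with a range from 40 ug/mL to 200 ug/mL.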

Compound 4, half-maximal inhibitory concentration: > 100 ug/mL
Compound 4: no number, only a limit; the forecaster's own chance of this, stated with the estimate: 25%; middle value at least 1.1-fold (0.04 log units) from the limit.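

In this assay compound 4 gives > 100 ug/mL, which is a limit of the assay and not a number. Amino in place of methoxy on an aromatic carbon gave an at least 2.8-fold higher number from compound 2 to compound 4 (0.45 log units; beyond the scatter), which runs in the same direction as a 3.8-fold higher number from compound 1 to compound 3 (0.58 log units; beyond the scatter), so across these two pairs the direction of the change carried over from one core to the other. The size of the step did not become readable on the second core, and two pairs cannot show that the change will behave alike on any further core: the same change on two cores in this assay, a 3.8-fold higher number (0.58 log units; beyond the scatter) from compound 1 to compound 3 and an at least 2.8-fold higher number (0.45 log units; beyond the scatter) from compound 2 to compound 4; the limit leaves it open whether they differ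

The compounds shown carry only methoxy and amino at the changed place, so what a methyl group, a carboxylic acid or a longer chain such as ethoxy would do there remains open. All four compounds also keep their hydroxyl group, which leaves open how a methyl ether or an amide in its stead would read in this assay.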